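Inverting the chain stereocentre of compound 3

A few compounds are considered here, and "the series" means these few. Any claim that something is new, unique, unknown or untested is made for them only; others in the source may bear on it.

Measured so far:
compound 1 `C[C@@H](Cn1ccc(-c2ccc(C#N)c(Cl)c2)n1)Nc1ccccn1`: in an ADME assay on PC-3 cells (Homo sapiens) for cytotoxicity, read by CCK-8 assay, with a stated time of 6 days (on this read-out lower numbers stand for stronger inhibition and higher numbers for weaker inhibition), compound 1 gives "not determined" (no result reported).
compound 2 `C[C@@H](Cn1ccc(-c2ccc(C#N)c(Cl)c2)n1)Nc1ncccn1`: in this assay compound 2 gives > 30000 nM, which is a limit of the assay and not a number.
compound 3 `C[C@@H](Cn1ccc(-c2ccc(C#N)c(Cl)c2)n1)Nc1ncnc2nc[nH]c12`: in this assay compound 3 gives 14100 nM.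

Among the compounds with values here, compound 3 holds the only single number in this assay; the other two entries are a limit and a blank. Within the data shown here, the one measured step is an at least 2.1-fold lower number from compound 2 to compound 3 (0.32 log units; beyond the scatter), from a value that is only a limit (the limit of > 30000 nM in this assay, at which 1 of the 3 values shown sits), so its true size is open at one end.

Compound 4 `C[C@H](Cn1ccc(-c2ccc(C#N)c(Cl)c2)n1)Nc1ncnc2nc[nH]c12` differs from compound 3 as follows: the two compounds have the same atoms and bonds and differ only in configuration as drawn: 1 of 1 stereo elements differ; a stereocentre at a saturated chain carbon is drawn S in compound 3 and R in compound 4. Among the measured compounds shown here, no measured pair in the set shares this kind of change, so nothing in the numbers bears on it directly; the one step on record concerns a swap of the group on the amine nitrogen and says nothing about the chain stereocentre. A configuration change alone can move the read-out either way or not at all, and with no comparator the expectation for this assay is a step of a 1.1-fold higher number from compound 3 to compound 4 (0.03 log units; within the scatter), that is, none beyond the scatter, with wide uncertainty in both directions. Compound 4 is therefore expected to give about 15000 nM, within 4000 nM to 45000 nM, with a fair chance that only a limit is reported.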

Compound 4, half-maximal inhibitory concentration: 1560 nM
Compound 4: middle estimate off by 9.6-fold (0.98 log units), on the high side; the whole stated range lies above it.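

In this assay the saturated chain carbon proves to be a position that responds to configuration, with a number at both ends of the step: going from S as drawn to R gives a 9.0-fold lower number from compound 3 to compound 4 (0.96 log units; beyond the scatter). This step can be laid on the stereocentre alone, because nothing else in the two structures changes: the fact that compounds 3 and 4 differ only in the configuration as drawn. The earlier step, a swap of the group on the amine nitrogen, starts from compound 2, whose value is a limit and not a number: the limit of > 30000 nM in this assay, at which 1 of the 4 values shown sits.

Compound 3 and compound 4 are the only pair shown that differ at the stereocentre, so it remains open whether R as drawn also gives the lower number with a different group on the amine nitrogen, such as the one in compound 2. Also open, from the compounds shown here alone, is how the read-out responds when the methyl on the stereocentre gives way to an ethyl group or a longer chain, or when the nitrile on the aryl ring gives way to an amide.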